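Adding a methoxy where every measured value is a limit

The source may report more compounds than this note shows. Statements on the series, on what has been measured and on what is new or still open speak of the compounds shown alone.

Compound 1 `COc1cc(C(=O)/C(C#N)=C/c2ccc(C(F)(F)F)cc2)cc(OC)c1OC` in an ADME assay on K562 cells (Homo sapiens) for cytotoxicity, read by MTT assay, with a stated time of 5 days (on this read-out lower numbers stand for stronger inhibition and higher numbers for weaker inhibition), gives > 10000 nM.
Compound 2 `COc1ccc(/C=C(\C#N)C(=O)c2cc(OC)c(OC)c(OC)c2)cc1Br` in this assay gives > 10000 nM.
Compound 3 `CCOC(=O)/C(=C/c1ccc(OC)cc1)C(=O)c1cc(OC)c(OC)c(OC)c1` in this assay gives > 10000 nM.

Each of these three values is a limit of the assay, not a measured number. Compound 3 therefore stands at the limit of > 10000 nM in this assay, at which 3 of the 3 values shown sit, and since the other two values are limits as well, no order among the three compounds can be read from them. Compound 4 `CCOC(=O)/C(=C/c1ccc(OC)c(OC)c1)C(=O)c1cc(OC)c(OC)c(OC)c1` differs from compound 3 by methoxy in place of hydrogen on an aromatic carbon. For the measured compounds named here, no measured pair here shows what such a change does in this assay. Because compound 3 sits at the limit of > 10000 nM in this assay, at which 3 of the 3 values shown sit, the expected step is a step that the limit leaves unreadable from compound 3 to compound 4, none beyond the scatter. Compound 4 is accordingly expected to give 15000 nM, within 5000 nM to 60000 nM, most likely again as a limit.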

Compound 4, half-maximal inhibitory concentration: > 10000 nM
Compound 4 ended at the assay's limit; the forecaster's own chance of this, stated with the estimate: 80%; the middle value lies beyond the limit too.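

No step can be read from compound 3 to compound 4, since both values are limits of the assay: the limit of > 10000 nM in this assay, at which 4 of the 4 values shown sit.

In this assay, going by these compounds, the effect of the added methoxy stays open, and so does any order among the four compounds.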